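The source may report more compounds than this note shows. Statements on the series, on what has been measured and on what is new or still open speak of the compounds shown alone.

Working notes on the series. In an ADME assay on Vero cells (Chlorocebus sabaeus) for cytotoxicity, read by MTT assay (a lower number here means that less compound is tolerated, a higher number that more compound is tolerated), compound 1 `O=C(Nc1ccc(S(=O)(=O)N2CCCC2)cc1)c1ccc(C(F)(F)F)cc1` gives > 300000 nM, which is a limit of the assay rather than a number (the limit of > 300000 nM in this assay, at which 1 of the 2 values shown sits). In this assay, going by the values given here, compound 2 `Cn1nc(C(F)(F)F)cc1C(=O)Nc1ccc(S(=O)(=O)N2CCCC2)cc1O` gives 288000 nM, the only numeric value in hand. Compound 3 `Cn1nc(C(F)(F)F)cc1C(=O)Nc1ccc(S(=O)(=O)N2CCCC2)cc1N` carries amino in place of hydroxy on an aromatic carbon, amino in place of hydroxy on an aromatic carbon. Among the compounds with values here, no measured step covers this change, and in this assay no shift beyond the usual scatter is expected in either direction. Compound 3 is therefore estimated at 280000 nM, within 140000 nM to 300000 nM, an expected step of a 1.0-fold lower number from compound 2 to compound 3 (0.01 log units; within the scatter).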

Compound 3, half-maximal cytotoxic concentration: > 300000 nM
Compound 3: only a limit was reported; the forecaster's own chance of this, stated with the estimate: 50%; middle value at least 1.0-fold (0.02 log units) from the limit.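

Amino in place of hydroxy on an aromatic carbon, ortho to a large group, gives an at least 1.0-fold higher number from compound 2 to compound 3 (0.01 log units; that floor lies within the scatter) in this assay. Going by these compounds alone, this is the first step read at this position, and it shows no lower number on leaving hydroxy for amino. The result for compound 3 is a limit, so the full size of the step stays unread because the values gather there: the limit of > 300000 nM in this assay, at which 2 of the 3 values shown sit.

From the compounds shown here alone, whether a methoxy group or a carboxylic acid at this position would give a number clearly lower than that of compound 2 remains open.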